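The compounds below may be only part of what the source reports. "The series", "measured", "known", "first", "only" and "open" are said of these compounds alone.

Measured compounds:
Compound 1, `CS(=O)(=O)Nc1ccc2c(c1)S(=O)(=O)N=C(c1c(O)c(-c3ccsc3)nn(CCC3CC3)c1=O)N2`: 0.517 h
Compound 2, `CC(C)CCn1nc(-c2ccccc2)c(O)c(C2=NS(=O)(=O)c3cc(NS(C)(=O)=O)ccc3N2)c1=O`: 0.633 h

In an in vitro ADME assay on microsomes from liver (Homo sapiens) for metabolic stability, tested at 5 uM (on this read-out higher numbers stand for a longer-lived compound and lower numbers for a shorter-lived compound), compound 1 gives 0.517 h and compound 2 gives 0.633 h. These two numbers lie within the usual scatter of each other, so compound 2 cannot be told apart from compound 1 on this read-out. The two compounds also differ in more than one place, so no single structural change can be tied to the gap between them.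

Compound 3, `C/C(=C\c1nn(CCC(C)C)c(=O)c(C2=NS(=O)(=O)c3cc(NS(C)(=O)=O)ccc3N2)c1O)C(F)(F)F`, has not yet been measured in this assay. It differs from compound 2 in one place: 2-(trifluoromethyl)prop-1-en-1-yl in place of phenyl on an aromatic carbon. Among the measured compounds shown here, no measured pair differs only at this position, so nothing in the data so far speaks to this particular change. With compound 1 at 0.517 h and compound 2 at 0.633 h sitting so close together, the expected step is a 1.1-fold lower number from compound 2 to compound 3 (0.02 log units; within the scatter), which is not beyond the scatter and in no set direction. Compound 3 is thus expected to give about 0.6 h in this assay, with a range from 0.3 h to 1.2 h.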

Compound 3, half-life: 0.167 h
Compound 3: the middle estimate sits 3.6-fold (0.56 log units) above what was measured, and the stated range ends above it.
By their numbers in this assay, from the lowest: compound 3; then compounds 1 and 2 (each within the scatter of the next).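

Among the compounds shown here, this is the first comparison in this assay that isolates a single position, and it shows that the group on this aromatic carbon, next to the ring nitrogen, can shift the half-life: putting 2-(trifluoromethyl)prop-1-en-1-yl in place of phenyl gives a 3.8-fold lower number from compound 2 to compound 3 (0.58 log units; beyond the scatter) on an otherwise unchanged structure. The earlier pair could not show this, since those two compounds differ in more than one place. The change removes an aromatic ring and brings in an open chain with a double bond and a trifluoromethyl group all at once, and no measurement shown here bears on why the half-life falls. The same single step also cannot say which of these parts of the swap matters most.

Open questions remain about other groups at this position, such as a pyridine ring, a saturated cyclohexyl ring or a simple isobutyl chain, and whether any of them would stay close to phenyl or fall as far as this chain. On these data alone, it is also open whether the same swap would give a similar step with a different chain on the ring nitrogen, such as a plain n-butyl chain.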